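The source may report more compounds than this note shows. Statements on the series, on what has been measured and on what is new or still open speak of the compounds shown alone.

Measured compounds in a functional assay on cells for agonist activity at Free fatty acid receptor 1 (Homo sapiens), read by calcium flux; on this read-out lower numbers stand for an effect already at smaller amounts and higher numbers for an effect only at larger amounts of compound:
- compound 1 `CC#CC(CC(=O)O)c1ccc(OCc2cccc(-c3c(C)cccc3C)c2)s1`: 210 nM
- compound 2 `Cc1cccc(C)c1-c1cccc(COc2ccc(CCC(=O)O)s2)c1`: 32 nM
- compound 3 `O=C(O)CCc1ccc(OCc2cccc(-c3ccncc3Cl)c2)s1`: 2010 nM

Compound 2 gives the lowest number of the three; the nearest is compound 1, the furthest compound 3, both steps beyond the scatter (a 6.6-fold lower number from compound 1 to compound 2 (0.82 log units; beyond the scatter); a 63-fold higher number from compound 2 to compound 3 (1.80 log units; beyond the scatter)).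

Compound 4 `Cc1cccc(C)c1-c1cccc(COc2ccc(C(CC(=O)O)C3CC3)s2)c1` differs from compound 2 by cyclopropyl in place of hydrogen on a saturated chain carbon bound to an aromatic carbon and a saturated chain carbon. The step from compound 1 to compound 2 bears on this: removing a group at that same saturated chain carbon gave a 6.6-fold lower number from compound 1 to compound 2 (0.82 log units; beyond the scatter). Adding cyclopropyl there is therefore expected to raise the number in this assay by a modest amount, beyond the scatter. The step from compound 2 to compound 3 concerns a different place and does not inform this change.

Compound 4 is thus estimated at 110 nM (range 40 nM to 400 nM), an expected 3.4-fold higher number from compound 2 to compound 4 (0.54 log units; beyond the scatter).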

Compound 4, half-maximal effective concentration: 3920 nM
Estimate against measurement, compound 4: 36-fold (1.55 log units) below, and the stated range ends below it.
By their numbers in this assay, from the lowest: compound 2; then compound 1; then compounds 3 and 4 (each within the scatter of the next).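

Cyclopropyl in place of hydrogen on the saturated chain carbon gives a 120-fold higher number from compound 2 to compound 4 (2.09 log units; beyond the scatter) in this assay, so a group at this carbon can cost far more than the earlier compounds indicated. Against prop-1-yn-1-yl at the same carbon, cyclopropyl gives a 19-fold higher number from compound 1 to compound 4 (1.27 log units; beyond the scatter) and the outcome here therefore depends on which group enters, not only on a group being present. Nothing available explains the gap between these two groups.

Open, from the compounds shown here alone, is whether methyl or hydroxyl at this carbon would stay closer to compound 2 than either group does.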